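The compounds below may be only part of what the source reports. "The series", "measured", "known", "first", "only" and "open" are said of these compounds alone.

Measured compounds:
Compound 1 `Cc1ccccc1Nc1nc(Nc2ccc(N3CCN(C(=O)OC(C)(C)C)CC3)cc2)ncc1Cl`: 2250 nM
Compound 2 `COc1cccc(CNc2nc(Nc3ccc(N4CCN(C)CC4)cn3)ncc2Cl)c1`: 19500 nM
Compound 3 `Cc1ccc(Nc2nc(Nc3ccc(N4CCN(C)CC4)cn3)ncc2Cl)cc1`: 11400 nM

These numbers come from a functional assay on MCF7 cells (Homo sapiens) for inhibition, read by CCK-8 assay, with a stated time of 48 h; a lower number here means a stronger inhibitor of growth, a higher number a weaker inhibitor of growth. Among the three, compound 3 gives the second highest number; compound 2 lies within the scatter of it, while compound 1 gives a lower number by a margin beyond the scatter. Compound 4 `COc1cccc(Nc2nc(Nc3ccc(N4CCN(C)CC4)cn3)ncc2Cl)c1` differs from compound 3 in one place: 3-methoxyphenyl in place of 4-methylphenyl on a nitrogen on an aromatic ring. Going by the values given here, the only measured step touching this same nitrogen is a 1.7-fold lower number from compound 2 to compound 3 (0.23 log units; within the scatter), which exchanged 3-methoxybenzyl for 4-methylphenyl and still stayed within the scatter. Among the compounds with values here, no measured step exchanges 4-methylphenyl for 3-methoxyphenyl, so there is no ground for expecting a move beyond the scatter. The expected step is a 1.1-fold lower number from compound 3 to compound 4 (0.06 log units; within the scatter). Compound 4 is therefore estimated at 10000 nM, with a range from 4000 nM to 25000 nM.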

Compound 4, concentration for 50% growth inhibition: 7540 nM
Compound 4: the middle estimate sits 1.3-fold (0.12 log units) above what was measured; the measured number falls inside the stated range.
By their numbers in this assay, from the lowest: compound 1; then compounds 4, 3 and 2 (each within the scatter of the next, the first and the last beyond it).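

In this assay, 3-methoxyphenyl and 4-methylphenyl on this nitrogen cannot be told apart, with a 1.5-fold lower number from compound 3 to compound 4 (0.18 log units; within the scatter). Going by these compounds alone, the clearer result comes from keeping the methoxy group and exchanging 3-methoxybenzyl for 3-methoxyphenyl, which gives a 2.6-fold lower number from compound 2 to compound 4 (0.41 log units; beyond the scatter), the first step at this nitrogen to pass the scatter. No evidence explains this step. Still open, from the compounds shown here alone, is how a longer chain, or a phenyl ring carrying a fluorine or a carboxylic acid, would behave on this nitrogen.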